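From pyrrolidin-2-yl to cyclopentylmethyl on the sulfonyl chain

A few compounds are considered here, and "the series" means these few. Any claim that something is new, unique, unknown or untested is made for them only; others in the source may bear on it.

In a functional assay, read by fluorescence and spectrophotometry, with a stated time of 1 h (on this read-out lower numbers stand for an effect already at smaller amounts and higher numbers for an effect only at larger amounts of compound), compound 1 (`CCCCCCCCCCCCS(=O)(=O)/C=C/c1ccc(O)c(O)c1`) gives 8500 nM, compound 2 (`O=S(=O)(/C=C/c1ccc(O)c(O)c1)CC1CC1`) gives 10500 nM and compound 3 (`O=S(=O)(/C=C/c1ccc(O)c(O)c1)CC1CCCN1`) gives 13800 nM. Compound 3 thus lies within the scatter of both other compounds. Compound 4 (`O=S(=O)(/C=C/c1ccc(O)c(O)c1)CCC1CCCC1`) has cyclopentylmethyl in place of pyrrolidin-2-yl on a saturated chain carbon bound to a sulfonyl sulfur. Among the measured compounds shown here, the one measured step at this place is a 1.3-fold higher number from compound 2 to compound 3 (0.12 log units; within the scatter), and it is small. Compound 1, with its much longer chain, also stays within the scatter of compound 3. No step beyond the scatter is therefore expected in this assay. The expected change is a 1.4-fold lower number from compound 3 to compound 4 (0.14 log units; within the scatter). For compound 4 the estimated value is 10000 nM, with an expected range of 5500 nM to 18000 nM.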

Compound 4, half-maximal effective concentration: 6800 nM
Estimate against measurement, compound 4: 1.5-fold (0.17 log units) above; the measured number falls inside the stated range.
By their numbers in this assay, from the lowest: compounds 4, 1, 2 and 3 (each within the scatter of the next, the first and the last beyond it).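

In this assay, this position now shows a step beyond the scatter, though a modest one: cyclopentylmethyl in place of pyrrolidin-2-yl gives a 2.0-fold lower number from compound 3 to compound 4 (0.31 log units; beyond the scatter). Cyclopentylmethyl in place of cyclopropyl gives a 1.5-fold lower number from compound 2 to compound 4 (0.19 log units; within the scatter), which stays within the scatter. Nothing available explains the larger step.

That step replaces a ring nitrogen with carbon and also adds a heavy atom, and the compounds shown cannot separate these two changes. As far as these compounds go, how an open-chain amine or a carboxylic acid would behave on this saturated chain carbon also remains open.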